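This account rests on a few compounds, and the source may have more. Where it says the series, first, only, none or still open, it means among the compounds named here.

Working notes on the series. The shared core carries a six-membered aromatic ring of carbon only on the pyrazole nitrogen, and two members have been measured so far in an assay on membranes from brain for binding affinity to adenosine receptor A1 (Rattus norvegicus), read by radioligand binding, tested at 20 uM; on this read-out higher numbers stand for more inhibition at the one concentration tested (going by the name of the read-out) and lower numbers for less inhibition. Compound 1 `Cn1c(=O)[nH]c2c(cnn2-c2ccc(Br)cc2)c1=N`, which carries a bromo on that ring, gives 34%, the higher of the two numbers in hand. Compound 2 `Cn1c(=O)[nH]c2c(cnn2-c2ccccc2N)c1=N` gives 0% in this assay, a figure lying well beyond the scatter from that of compound 1; the two differ in more than one place, so the pair tells only what its values show.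

The next member is compound 3 `Cn1c(=O)[nH]c2c(cnn2-c2ccc(F)cc2)c1=N`, which is compound 1 with fluoro in place of bromo on an aromatic carbon. For the measured compounds named here, no pair in the set isolates this change. The expected step from compound 1 to compound 3 in this assay, a number 12 percentage points lower from compound 1 to compound 3 (beyond the scatter), is a modest loss, at the edge of the usual scatter. Compound 3 is accordingly estimated at 22%, with a likely range from 5% to 40%.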

Compound 3, a percentage reported as inhibition, at one concentration (the size of the read-out at that concentration, not a potency): 26%
Compound 3: middle estimate off by 4 percentage points, on the low side, and the stated range covers the measured number.
By their numbers in this assay, from the lowest: compound 2; then compounds 3 and 1 (each within the scatter of the next).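

In this assay, for the compounds shown here, fluoro in place of bromo on an aromatic carbon, para to a large group, gives a number 8 percentage points lower from compound 1 to compound 3 (within the scatter) and is the first change that can be read in one place. At this position, the two halogens are therefore not separated by this read-out, and a single halogen atom of either kind is compatible with inhibition at the one concentration tested. Nothing in hand bears on the reason for this result.

On these data alone, whether this level of inhibition depends on a halogen at all remains open, since a methoxy group, an amine or a carboxylic acid at the same position could hold it or lose it. The effect of a hydrogen there, with no substituent on the ring, is equally unsettled.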